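The source may hold more compounds than are shown below. What is called first, only, known or untested is meant among the compounds shown, and "the series" means these compounds.

Of the compounds shown here, two so far define the series in an ADME assay on microsomes from liver (Mus musculus) for metabolic stability, read by LC-MS, using NADPH, with stated times of 10 min and 30 min; a higher number here means faster removal of the compound, a lower number slower removal. Compound 1 (`O=C1c2ccc(Cl)cc2CN1c1cccnc1`) gives 76.5 mL/min/kg and compound 2 (`CC1CN(c2cccnc2)C(=O)c2ccc(Cl)cc21`) gives 45 mL/min/kg. These two values lie within the usual scatter of each other, so neither compound can be ranked on this read-out.

Compound 3 (`CCC1c2cc(Cl)ccc2C(=O)N1c1cccnc1`) is the next to be read. It carries ethyl in place of hydrogen on a saturated ring carbon of the core of compound 1, next to the ring nitrogen: ethyl in place of hydrogen on a saturated ring carbon. Within the data shown here, no measured pair isolates this change, so the data give no direct size for it. The working expectation is therefore no step beyond the scatter, with the direction left open. The expected step is a 1.2-fold lower number from compound 1 to compound 3 (0.07 log units; within the scatter). The estimated value for compound 3 is 65 mL/min/kg, with an expected range from 32 mL/min/kg to 125 mL/min/kg.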

Compound 3, clearance: 65.9 mL/min/kg
Compound 3: middle estimate off by 1.0-fold (0.01 log units), on the low side, within the range that was stated.
By their numbers in this assay, from the lowest: compounds 2, 3 and 1 (each within the scatter of the next).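

In this assay, among these compounds, ethyl in place of hydrogen on a saturated ring carbon, next to the ring nitrogen, gives a 1.2-fold lower number from compound 1 to compound 3 (0.06 log units; within the scatter) and so provides the first measured single-place step. That step lies within the scatter, so on this read-out the position takes ethyl on the core of compound 1 without a change that can be read. No supporting measurement bears on this result.

As far as these compounds go, whether a longer chain, a hydroxyl group or an amine on this same ring carbon would give a step beyond the scatter remains open. Also open, from the compounds shown here alone, is how the number responds to replacing the pyridin-3-yl group, which is the same in all three compounds.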